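Swapping an Aromatic Ring for a Cyclohexene

This account rests on a few compounds, and the source may have more. Where it says the series, first, only, none or still open, it means among the compounds named here.

Compound 2 `O=C(O)c1csc(-n2nc(-c3ccc(F)cc3)c3ccccc32)n1` gives 4.5 nM in an assay on isolated protein for antagonist activity at prostaglandin E2 receptor EP1 subtype (Homo sapiens), read by reporter gene assay (on this read-out lower numbers stand for stronger inhibition and higher numbers for weaker inhibition), the lowest of the two numbers at hand; compound 1 `O=C(O)c1csc(-n2nc(-c3ccccc3)c3ccc(O)cc32)n1` gives 140 nM, and the gap between them lies beyond the usual scatter. Compound 3 `O=C(O)c1csc(-n2nc(C3=CCCCC3)c3ccccc32)n1` has not yet been measured. It differs from compound 2 in one place: cyclohex-1-en-1-yl in place of 4-fluorophenyl on an aromatic carbon. Among the compounds with values here, no measured pair shows a swap of this kind, so the expectation rests on the structural change alone, and it leans toward weaker inhibition: a step of a 5.6-fold higher number from compound 2 to compound 3 (0.74 log units; beyond the scatter) is expected. Compound 3 is therefore estimated at 25 nM, with a likely range from 6 nM to 120 nM.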

Compound 3, half-maximal inhibitory concentration: 4 nM
Compound 3: the middle estimate sits 6.3-fold (0.80 log units) above what was measured; measured number below the stated range.
By their numbers in this assay, from the lowest: compounds 3 and 2 (each within the scatter of the next); then compound 1.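

At this position on the five-membered aromatic ring, the change brings a 1.1-fold lower number from compound 2 to compound 3 (0.05 log units; within the scatter) and so leaves inhibition level. A non-aromatic ring with one double bond therefore serves here as well as a fluorinated aromatic ring, so neither the aromatic ring nor the fluorine is needed in this pair. Nothing available explains why the two groups match.

On these data alone, whether a fully saturated cyclohexyl ring, a small methyl group or an amine would hold this level remains open. So does how far the ring size can change, for instance to cyclopentenyl.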